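Cyclohexyl diaryl urea series: aryl swap from compound 3

This account rests on a few compounds, and the source may have more. Where it says the series, first, only, none or still open, it means among the compounds named here.

Measured so far:
compound 1 `O=C(Nc1ccc([N+](=O)[O-])cc1)N[C@H]1CC[C@H](Oc2ccc(F)cc2)CC1`: 2300 nM
compound 2 `O=C(Nc1ccc(F)cc1)N[C@H]1CC[C@H](Oc2ccc(F)cc2)CC1`: 20000 nM
compound 3 `O=C(Nc1ccccc1[N+](=O)[O-])N[C@H]1CC[C@H](Oc2ccc(F)cc2)CC1`: 3500 nM

In a functional assay on CRL2813 cells (Homo sapiens) for cytotoxicity, read by sulforhodamine B assay, with a stated time of 5 days (on this read-out lower numbers stand for stronger inhibition and higher numbers for weaker inhibition), compound 3 stands second highest of the three numbers; its nearest neighbour is compound 1, a 1.5-fold higher number from compound 1 to compound 3 (0.18 log units; within the scatter) being within the scatter, and its furthest is compound 2, with a 5.7-fold lower number from compound 2 to compound 3 (0.76 log units; beyond the scatter) lying beyond it. Compound 4 `O=C(Nc1cccc(I)c1)N[C@H]1CC[C@H](Oc2ccc(F)cc2)CC1` differs from compound 3 in one place: 3-iodophenyl in place of 2-nitrophenyl on an amide-type nitrogen.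

Going by the values given here, two measured steps bear on this. Among the compounds with values here, the one step that exchanges a nitro for a halogen on the aryl ring, an 8.7-fold higher number from compound 1 to compound 2 (0.94 log units; beyond the scatter), ran toward a higher number, and the reverse pairing, a 5.7-fold lower number from compound 2 to compound 3 (0.76 log units; beyond the scatter), ran lower. Within the data shown here, no compound in the set carries iodine, so how far a 3-iodophenyl sits from a 4-fluorophenyl cannot be read from these numbers. On the nitro-to-halogen precedent a modestly higher number is expected for compound 4, with wide uncertainty.

Compound 4 is expected to give about 9000 nM, with a range of 3000 nM to 25000 nM. The step expected from this estimate is a 2.6-fold higher number from compound 3 to compound 4 (0.41 log units; beyond the scatter).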

Compound 4, half-maximal inhibitory concentration: 5200 nM
Beside the measured number, compound 4's estimate is 1.7-fold (0.24 log units) above it, within the range that was stated.
By their numbers in this assay, from the lowest: compounds 1, 3 and 4 (each within the scatter of the next, the first and the last beyond it); then compound 2.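

In this assay, a nitro group is not needed on this aryl ring for a value in this range, since 3-iodophenyl and 2-nitrophenyl differ only within the scatter, with a 1.5-fold higher number from compound 3 to compound 4 (0.17 log units; within the scatter). A halogen on this ring also does not by itself give the weak value of compound 2, given a 3.8-fold lower number from compound 2 to compound 4 (0.59 log units; beyond the scatter), although 4-nitrophenyl still keeps an edge over 3-iodophenyl, with a 2.3-fold higher number from compound 1 to compound 4 (0.35 log units; beyond the scatter). No measurement here accounts for these steps.

The halogen and its place on the ring change together between 4-fluorophenyl and 3-iodophenyl, so neither change can be credited alone. On these data alone, how an amine or a carboxylic acid on this aryl ring would compare with the nitro and iodo groups remains open.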